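This account rests on a few compounds, and the source may have more. Where it says the series, first, only, none or still open, it means among the compounds named here.

In a functional assay on HL-60 cells (Homo sapiens) for cytotoxicity, read by CellTiter-Blue, with a stated time of 48 h (a lower number here means a stronger inhibitor, a higher number a weaker inhibitor), three compounds on a shared core have been measured so far. Compound 1 `CCCOC(=O)CC1C(C(=O)OCCC)=C(N)Oc2ccc(-c3cc(OC)cc(OC)c3)cc21` gives 7600 nM. Compound 3 `CCOC(=O)CC1C(C(=O)OCC)=C(N)Oc2ccc(-c3ccc(F)cc3)cc21` gives 72100 nM, the higher of the two numbers and beyond the scatter from compound 1. Compound 2 `COc1cc(OC)cc(-c2ccc3c(c2)C(CC(=O)OCC2CO2)C(C(=O)OCC2CO2)=C(N)O3)c1` reads > 80000 nM, which is a limit of the assay and not a number.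

Compound 4 `CCOC(=O)CC1C(C(=O)OCC)=C(N)Oc2ccc(-c3ccncc3)cc21` carries pyridin-4-yl in place of 4-fluorophenyl on an aromatic carbon. Among the measured compounds shown here, no measured pair shows this change, so only a small step toward a lower number is expected in this assay, probably within the scatter. The estimated step runs a 1.4-fold lower number from compound 3 to compound 4 (0.16 log units; within the scatter). Compound 4 is expected at 50000 nM, with an estimated range of 18000 nM to 110000 nM.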

Compound 4, half-maximal inhibitory concentration: 10200 nM
Beside the measured number, compound 4's estimate is 4.9-fold (0.69 log units) above it, and the stated range ends above it.
By their numbers in this assay, from the lowest: compounds 1 and 4 (each within the scatter of the next); then compound 3. At a limit, above all of these: compound 2.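

In this assay the shared core now has a one-place comparison at this aromatic carbon: a 7.1-fold lower number from compound 3 to compound 4 (0.85 log units; beyond the scatter) with pyridin-4-yl in place of 4-fluorophenyl. The step lies beyond the scatter, so the number in this pair responds to the identity of this aromatic ring. Nothing measured here gives a cause for the step.

Still open, as far as these compounds go, is whether pyridin-3-yl or a 4-aminophenyl group at this carbon gives a step of similar size. Also open, from the compounds shown here alone, is whether the same change holds with the propyl esters of compound 1.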